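This account rests on a few compounds, and the source may have more. Where it says the series, first, only, none or still open, it means among the compounds named here.

Of the compounds shown here, two have been measured in an assay on cells for displacement of a labelled ligand from prostaglandin E2 receptor EP4 subtype (Homo sapiens), read by scintillation counting, tested at 10 uM; on this read-out lower numbers stand for less inhibition and higher numbers for more inhibition at the one concentration tested (going by the name of the read-out). Compound 1 `Cc1oc(CCC(=O)O)cc1COc1ccc(-c2ccccc2)cc1` gives 63% in this assay, the higher of the two numbers. Among the compounds with values here, compound 2 `Cc1oc(C(=O)O)cc1COc1ccc(C(C)(C)c2ccccc2)cc1` gives 23% in this assay, a number beyond the scatter below compound 1; no single-change step connects the two, so only their two values are compared. Compound 3 `Cc1oc(CC(=O)O)cc1COc1ccc(-c2ccccc2)cc1` awaits measurement. It differs from compound 1 in one place: carboxy in place of carboxymethyl on a saturated chain carbon bound to an aromatic carbon. Compound 2 also carries a carboxy group and gives the lower number, though its tail differs as well. A downward step beyond the scatter is expected, estimated as a number 23 percentage points lower from compound 1 to compound 3 (beyond the scatter). Compound 3 is expected to give 40% in this assay, with a range from 15% to 65%.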

Compound 3, a percentage reported as inhibition, at one concentration (the size of the read-out at that concentration, not a potency): 61%
Compound 3: middle estimate off by 21 percentage points, on the low side; the measured number falls inside the stated range.
By their numbers in this assay, from the lowest: compound 2; then compounds 3 and 1 (each within the scatter of the next).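

Exchanging 2-carboxyethyl for carboxymethyl on the core of compound 1 gives, in this assay, a number 2 percentage points lower from compound 1 to compound 3 (within the scatter), so this read-out does not separate the two chains at this place. The carboxy end therefore need not sit on the longer of these two chains for the number to stay within the scatter. Nothing measured here bears on why the two chains read alike. Still open, as far as these compounds go, is how a longer chain ending in carboxy would read in this assay. From the compounds shown here alone, a primary amide in place of the carboxy end is equally open.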